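The compounds below may be only part of what the source reports. "The series", "measured", "known", "first", "only" and "open" are said of these compounds alone.

Compound 1 `COc1cccc(OC)c1OCCNCCOc1ccccc1OCc1ccccc1` is the parent of this small set, with the unsubstituted benzyl group at the end. In a functional assay on PC-3 cells (Homo sapiens) for cytotoxicity, read by sulforhodamine B assay (a lower number here means a stronger inhibitor of growth, a higher number a weaker inhibitor of growth), compound 1 gives 26900 nM, the highest of the three numbers measured, so it is the weakest of the three growth inhibitors. Compound 2 `COc1cccc(OC)c1OCCNCCOc1ccccc1OCc1cccc(Cl)c1`, which bears chloro in place of hydrogen on an aromatic carbon, gives 5900 nM in this assay, and compound 3 `COc1cccc(OC)c1OCCNCCOc1ccccc1OCc1cccc(C)c1`, which bears methyl in place of hydrogen on an aromatic carbon, gives 12000 nM. The step of a 4.6-fold lower number from compound 1 to compound 2 (0.66 log units; beyond the scatter) and the step of a 2.2-fold lower number from compound 1 to compound 3 (0.35 log units; beyond the scatter) both point toward stronger inhibition, while the step of a 2.0-fold higher number from compound 2 to compound 3 (0.31 log units; beyond the scatter) shows the methyl compound somewhat behind the chloro compound.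

Compound 4 `COc1cccc(OC)c1OCCNCCOc1ccccc1OCc1ccc(C)cc1` is not yet measured. It differs from compound 1 by methyl in place of hydrogen on an aromatic carbon. For the measured compounds named here, the one measured step that bears directly on it is the step from compound 1 to compound 3, which also puts methyl in place of hydrogen on an aromatic carbon, though at another carbon of that ring. Given that step, a modest move toward a lower number is expected for compound 4, of about the same size as a 2.2-fold lower number from compound 1 to compound 3 (0.35 log units; beyond the scatter); the expected step is a 2.2-fold lower number from compound 1 to compound 4 (0.35 log units; beyond the scatter). Compound 4 is therefore estimated at 12000 nM in this assay, with a range from 5000 nM to 30000 nM.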

Compound 4, concentration for 50% growth inhibition: 7800 nM
The estimate for compound 4 lay 1.5-fold (0.19 log units) above the measured number; measured number inside the range.
By their numbers in this assay, from the lowest: compounds 2, 4 and 3 (each within the scatter of the next, the first and the last beyond it); then compound 1.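

With methyl on the ring carbon para to a large group, a 3.4-fold lower number from compound 1 to compound 4 (0.54 log units; beyond the scatter) again moves the number down from the parent in this assay, so the gain seen earlier with methyl is not confined to a single ring carbon. The two placements of methyl cannot be told apart here, as a 1.5-fold lower number from compound 3 to compound 4 (0.19 log units; within the scatter) stays within the usual scatter of the assay. The gap that separated the methyl compound 3 from the chloro compound 2 also does not reappear with 4-methylbenzyl, for a 1.3-fold higher number from compound 2 to compound 4 (0.12 log units; within the scatter) is likewise within the scatter, leaving compound 4 level with compound 2 on these numbers.

Still open, as far as these compounds go, is how chloro behaves on the ring carbon para to a large group, and so whether methyl and chloro would also stay level at that place. Nor do these compounds show how far the benzyl ring tolerates other groups there, such as methoxy, an amine, a carboxylic acid or a longer chain like propyl. No measurement accompanying these compounds accounts for the steps between them.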